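Estimating compound 4 from one earlier step

This account rests on a few compounds, and the source may have more. Where it says the series, first, only, none or still open, it means among the compounds named here.

In a functional assay on HeLa cells (Homo sapiens) for cytotoxicity, read by MTT assay, in the presence of a further agent that is not named here (a lower number here means a stronger inhibitor, a higher number a weaker inhibitor), compound 1 `CC1(C)O[C@H]([C@H]2COC(C)(C)O2)[C@@H](C2CC(=O)SS2)O1` gives 16900 nM and compound 2 `CC1(C)O[C@H]([C@H]2COC(C)(C)O2)[C@@H](C2CC(=O)S[S+]2[O-])O1` gives 12600 nM as its reading. Compound 3 `CC(C)(C)[Si](C)(C)O[C@@H]1[C@H](O[Si](C)(C)C(C)(C)C)[C@@H](C2CC(=O)SS2)O[C@H]1n1ccc(=O)[nH]c1=O` gives 7840 nM in this assay and so stands lower than compound 1 by more than the scatter, the spread seen when a measurement is repeated, while its distance to compound 2 lies within that scatter.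

Compound 4 `CC(C)(C)[Si](C)(C)O[C@@H]1[C@H](O[Si](C)(C)C(C)(C)C)[C@@H](C2CC(=O)S[S+]2[O-])O[C@H]1n1ccc(=O)[nH]c1=O` differs from compound 3 in one place: a group of 7 heavy atoms (3 carbon, 2 oxygen, 2 sulfur; one five-membered non-aromatic ring with 2 hetero atoms) in place of a group of 6 heavy atoms (3 carbon, 1 oxygen, 2 sulfur; one five-membered non-aromatic ring with 2 hetero atoms), on a saturated ring carbon and the rest of the structure is shared. That place is next to the ring oxygen of a five-membered non-aromatic ring with 1 oxygen.

One measured step makes the same swap on another core: a 1.3-fold lower number from compound 1 to compound 2 (0.13 log units; within the scatter) and that step stays within the scatter. A single step is thin evidence, and it comes from a different core, so no step beyond the scatter is expected in this assay for this swap. The expected change is a 1.2-fold lower number from compound 3 to compound 4 (0.08 log units; within the scatter) and this estimate lies within the scatter. Compound 4 is estimated at 6500 nM in this assay with an expected range from 3500 nM to 12000 nM around that estimate.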

Compound 4, half-maximal inhibitory concentration: 2670 nM
Beside the measured number, compound 4's estimate is 2.4-fold (0.39 log units) above it, outside the stated range (below it).
By their numbers in this assay, from the lowest: compound 4; then compounds 3, 2 and 1 (each within the scatter of the next, the first and the last beyond it).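

On the core of compound 3, at this place on a saturated ring carbon of a five-membered non-aromatic ring with 1 oxygen, the reading in this assay does respond to this swap. Within the data shown here, putting the group of 7 heavy atoms in place of the group of 6 heavy atoms gives a 2.9-fold lower number from compound 3 to compound 4 (0.47 log units; beyond the scatter), and this is the first time the swap produces a step larger than the spread of repeat measurements. Even so, the two cores cannot yet be said to respond differently, as the gap between their steps is itself no larger than the noise allows:  the same change on two cores in this assay, a 1.3-fold lower number (0.13 log units; within the scatter) from compound 1 to compound 2 and a 2.9-fold lower number (0.47 log units; beyond the scatter) from compound 3 to compound 4, 2.2-fold (0.34 log units) apart, within the scatter of two such steps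

The compounds shown leave open how a group of a different kind at this place, such as an amine or a carboxylic acid, would read in this assay, as only these two sulfur-containing rings appear there. They also leave open whether a third core would give a step closer to the one on the core of compound 1 or to the one on the core of compound 3.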